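Changing one aromatic group in a cytotoxicity series

A few compounds are considered here, and "the series" means these few. Any claim that something is new, unique, unknown or untested is made for them only; others in the source may bear on it.

Compound 1 `N#Cc1ccc(-c2c[nH]cc2C(c2ccc(Cl)cc2Cl)n2ccnc2)cc1` gives 15000 nM
Compound 2 `O=[N+]([O-])c1ccc(-c2c[nH]cc2C(c2ccc(Cl)cc2Cl)n2ccnc2)cc1` gives 16900 nM
Compound 3 `CSc1ccc(-c2c[nH]cc2C(c2ccc(Cl)cc2Cl)n2ccnc2)cc1` gives 7220 nM

In an ADME assay on L6 cells (Rattus norvegicus) for cytotoxicity, read by fluorescence and resazurin assay, with a stated time of 72 h (on this read-out lower numbers stand for higher toxicity in this test and higher numbers for lower toxicity in this test), compound 3 gives 7220 nM as the lowest number of the three. Compound 4 `Clc1ccc(-c2c[nH]cc2C(c2ccc(Cl)cc2Cl)n2ccnc2)c(Cl)c1` has not been measured yet. Compared with compound 3, it carries 2,4-dichlorophenyl in place of 4-(methylsulfanyl)phenyl on an aromatic carbon at the same place on the shared core.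

Within the data shown here, three measured steps bear on this, each changing that phenyl group: a 1.1-fold higher number from compound 1 to compound 2 (0.05 log units; within the scatter) and a 2.1-fold lower number from compound 1 to compound 3 (0.32 log units; beyond the scatter) and a 2.3-fold lower number from compound 2 to compound 3 (0.37 log units; beyond the scatter) are what was seen. None of these steps is large, and none adds chlorine to that group. Only a small step of unclear direction, possibly none beyond the scatter, is therefore expected in this assay for this change. The expected change is a 1.1-fold lower number from compound 3 to compound 4 (0.05 log units; within the scatter) in this estimate. For compound 4 the estimated value is 6500 nM with an expected range from 2500 nM to 16000 nM in this test.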

Compound 4, half-maximal cytotoxic concentration: 9860 nM
For compound 4 the middle estimate is 1.5-fold (0.18 log units) below the measured one; low and high end bracket the measured number.
By their numbers in this assay, from the lowest: compounds 3, 4, 1 and 2 (each within the scatter of the next, the first and the last beyond it).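

In this assay the 2,4-dichlorophenyl group, the first here to carry two chlorines on that ring, gives a number among those of the earlier groups (a 1.4-fold higher number from compound 3 to compound 4 (0.14 log units; within the scatter)) and (a 1.7-fold lower number from compound 2 to compound 4 (0.23 log units; within the scatter)) and (a 1.5-fold lower number from compound 1 to compound 4 (0.18 log units; within the scatter)). All three steps lie within the scatter, so compound 4 cannot be told apart from any earlier compound, even though compound 2 and compound 3 differ beyond it.

As far as these compounds go, whether an amine or a carboxylic acid on this phenyl ring would give a larger step remains open. Nothing available explains these numbers.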